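Swapping the Aryl Group on a Shared Acid-Bearing Core

A few compounds are considered here, and "the series" means these few. Any claim that something is new, unique, unknown or untested is made for them only; others in the source may bear on it.

Measured compounds:
compound 1, `O=C(O)CCCCOc1cc(-c2ccccc2)c2ccccc2n1`: 0%
compound 2, `CC(=O)Nc1ccc(-c2cc(OCCCCC(C)(C)C(=O)O)nc3ccccc23)cc1`: 23%

In an assay on membranes from spleen (Cavia porcellus) for binding affinity to leukotriene B4 receptor 1 (Homo sapiens), tested at 10 uM (a lower number here means less inhibition, a higher number more inhibition at the concentration tested (going by the name of the read-out)), compound 1 gives 0%. Compound 2 gives 23% in this assay, the higher of the two numbers, and its gap to compound 1 lies beyond the usual scatter of such measurements. Compound 3, `COc1ccccc1-c1cc(OCCCCC(C)(C)C(=O)O)nc2ccccc12`, has not been measured yet. It differs from compound 2 in a single place: 2-methoxyphenyl in place of 4-acetamidophenyl on an aromatic carbon. Among the measured compounds shown here, no measured pair isolates this exchange, so what can be said rests only on the two numbers in hand: compound 1, which lacks the 4-acetamidophenyl, gives 0%, while compound 2, which carries it, gives 23%. On that basis the account expects a moderate decrease, a number 13 percentage points lower from compound 2 to compound 3 (beyond the scatter), when the 4-acetamidophenyl is exchanged for the 2-methoxyphenyl. For compound 3 the expected inhibition in this assay is 10%, with a range from 0% to 30%.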

Compound 3, a percentage reported as inhibition, at one concentration (the size of the read-out at that concentration, not a potency): 36%
Compound 3: the middle estimate sits 26 percentage points below what was measured; measured number above the stated range.
By their numbers in this assay, from the lowest: compound 1; then compound 2; then compound 3.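

Among the compounds shown here, the exchange of 4-acetamidophenyl for 2-methoxyphenyl gives the first reading of a change made in one place only, on the aromatic carbon opposite the ring nitrogen: in this assay it gives a number 13 percentage points higher from compound 2 to compound 3 (beyond the scatter), a modest step. It shows that the number is higher after this change of aryl group, and that inhibition at the concentration tested does not depend on the 4-acetamidophenyl, since the entering group has fewer heavy atoms and no hydrogen-bond donor, yet compound 3 gives 36% in this assay. Nothing available here accounts for the direction or size of this step.

The compounds shown leave open whether the methoxy group contributes at all, or whether a plain phenyl, or a phenyl carrying a hydroxyl or an amine, would serve as well on the same core. Since each compound is read at a single concentration, they also leave open how these inhibition numbers relate to potency.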